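This account rests on a few compounds, and the source may have more. Where it says the series, first, only, none or still open, it means among the compounds named here.

Working notes on the series in a functional assay on ECa-109 cells (Homo sapiens) for cytotoxicity, read by MTT assay, with a stated time of 48 h; on this read-out higher numbers stand for weaker inhibition and lower numbers for stronger inhibition. Compound 1 `COc1ccc(-c2c[nH]c(=O)n2-c2cc(OC)c(OC)c(OC)c2)cc1OC` reads > 50000 nM, a limit of the assay and not a number. Compound 2 `COc1ccc(-c2c[nH]c(=O)n2-c2cc(OC)c(OC)c(OC)c2)cc1[N+](=O)[O-]` reads > 50000 nM, again a limit. Compound 3 `COc1cc(NC(=O)n2cc(-c3ccc(O)cc3)n(-c3cc(OC)c(OC)c(OC)c3)c2=O)cc(OC)c1OC` reads > 50000 nM, also a limit, so its position is bounded on one side only. Among the compounds with values here, the series so far comes down to the limit of > 50000 nM in this assay, at which 3 of the 3 values shown sit.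

Compound 4 `COc1ccc(-c2cn(C(=O)Nc3cc(OC)c(OC)c(OC)c3)c(=O)n2-c2cc(OC)c(OC)c(OC)c2)cc1OC` departs from compound 3 at one place: 3,4-dimethoxyphenyl in place of 4-hydroxyphenyl on an aromatic carbon. In words, it has 3,4-dimethoxyphenyl in place of 4-hydroxyphenyl on an aromatic carbon.

Within the data shown here, the only measured step, a step that the two limits leave unreadable from compound 1 to compound 2, has no readable size and involves a different exchange, so it gives nothing to carry over. Compound 1 already carries the 3,4-dimethoxyphenyl group and reads > 50000 nM, a limit, so that group alone is not expected to bring a measurable value. No direction can be assigned, and no step beyond the scatter is expected in this assay. The estimated step is a number no higher from compound 3 to compound 4 (the limit leaves the size open). A reading at the same limit is the most likely outcome. For compound 4 the estimate is 50000 nM, with an expected range from 15000 nM to 100000 nM.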

Compound 4, half-maximal inhibitory concentration: > 50000 nM
Compound 4 ended at the assay's limit; the forecaster's own chance of this, stated with the estimate: 70%; the middle value sits exactly at the limit.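

Compound 4 at > 50000 nM is a limit of the assay and not a number. Compound 3 also stands at a limit, so no step can be read between compound 3 and compound 4 in this assay at all. The compounds shown leave open whether any change on the shared core brings a measurable value, since the series still comes down to one reading: the limit of > 50000 nM in this assay, at which 4 of the 4 values shown sit.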